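The source may hold more compounds than are shown below. What is called first, only, known or untested is meant among the compounds shown, and "the series" means these compounds.

Measured so far in a functional assay on SK-MEL-2 cells (Homo sapiens) for cytotoxicity; a higher number here means a weaker inhibitor, a lower number a stronger inhibitor:

- compound 1 `Cc1ccc(S(=O)(=O)N2CC(c3ccc(Br)cc3)NC2=O)cc1`: > 253000 nM
- compound 2 `Cc1ccc(C2CNC(=O)N2S(=O)(=O)c2ccc3c(c2)CCC3)cc1`: 88600 nM
- compound 3 `Cc1ccc(C2CNC(=O)N2S(=O)(=O)c2ccc(C)cc2)cc1`: 234000 nM

Compound 1 gives > 253000 nM as its entry, which is a limit of the assay and not a number. That leaves two true numbers to compare. Compound 2, at 88600 nM, has the lower of them. The nearest neighbour is compound 3 at 234000 nM and this gap lies beyond the usual scatter of repeated measurements.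

Compound 4 `O=C1NCC(c2ccccc2)N1S(=O)(=O)c1ccc2c(c1)CCC2` has not yet been measured. It differs from compound 2 by one small change hydrogen in place of methyl on an aromatic carbon, para to a large group, so that 4-methylphenyl becomes phenyl.

Among the measured compounds shown here, no measured pair isolates this change, so the data offer no direct guide to its size or direction. Removing a single methyl is expected to move the number only a little, and the starting point is compound 2 at 88600 nM. The expected change, a 1.4-fold higher number from compound 2 to compound 4 (0.13 log units; within the scatter), is small, towards a slightly higher number, and probably within the scatter. The estimate for compound 4 is 120000 nM, with an expected range of 50000 nM to 250000 nM.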

Compound 4, half-maximal inhibitory concentration: 39000 nM
For compound 4 the middle estimate is 3.1-fold (0.49 log units) above the measured one; measured number below the stated range.
By their numbers in this assay, from the lowest: compound 4; then compound 2; then compound 3. At a limit, above all of these: compound 1.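

Among the compounds shown here, the step of a 2.3-fold lower number from compound 2 to compound 4 (0.36 log units; beyond the scatter) in this assay comes from the only pair so far that isolates the methyl of the 4-methylphenyl group. The step is modest but lies beyond the scatter, so at this place, para to a large group, the methyl is not needed for the activity seen here, and plain phenyl gives the lower number of the two. Compound 1 carries a limit of the assay and not a number, so it adds nothing to this reading: the limit of > 253000 nM in this assay, at which 1 of the 4 values shown sits.

As far as these compounds go, only this one replacement can be read, on a single background, so it stays open whether the same change would give a similar step with another group on the sulfonyl side of the shared core. From the compounds shown here alone, it is also open what a methoxy group, an amine or a carboxylic acid would do at this place, and comparing hydrogen with methyl alone supports no wider trend.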